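Cyano for isopropyl on the carbinol-bearing ring

This account rests on a few compounds, and the source may have more. Where it says the series, first, only, none or still open, it means among the compounds named here.

Compound 1 `CSc1ccc(COCC#CC(O)c2ccc(C(C)C)cc2)cc1` gives the lowest of the two numbers in an assay on isolated protein for inhibition of Polyunsaturated fatty acid 5-lipoxygenase (Homo sapiens) (on this read-out lower numbers stand for stronger inhibition and higher numbers for weaker inhibition), so far: compound 1 gives 8000 nM. Compound 2 `COc1cccc(C(O)C#CCOCc2ccc(SC)cc2)c1OC` stands a higher number away, beyond the scatter, as in this assay compound 2 gives 69000 nM; the two differ in several places at once, so no single step can be read from that pair.

Compound 3 `CSc1ccc(COCC#CC(O)c2ccc(C#N)cc2)cc1` has not been measured. It is made from compound 1 by cyano in place of isopropyl on an aromatic carbon. Among the compounds with values here, no measured pair shows the effect of this change on this assay. Within the data shown here, the only comparison available is compound 2, whose value in this assay 69000 nM shows that a different substitution of this ring gave a weaker result, yet that pair is not a one-place step.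

The step from compound 1 to compound 3 is expected to be a moderate loss, a 2.5-fold higher number from compound 1 to compound 3 (0.40 log units; beyond the scatter). Compound 3 is estimated at 20000 nM in this assay, with a range from 6000 nM to 70000 nM.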

Compound 3, half-maximal inhibitory concentration: 41000 nM
Compound 3: middle estimate off by 2.1-fold (0.31 log units), on the low side; the range from low to high includes it.
By their numbers in this assay, from the lowest: compound 1; then compounds 3 and 2 (each within the scatter of the next).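

In this assay, within the data shown here, cyano in place of isopropyl on this aromatic carbon, para to a large group, gives a 5.1-fold higher number from compound 1 to compound 3 (0.71 log units; beyond the scatter) and provides the first one-place reading. The position therefore responds to its substituent, with isopropyl giving the lower number of the two groups; the earlier pair differed in several places at once and could not show this. No measurement at hand accounts for this step.

The compounds shown do not separate the loss of isopropyl from the entry of cyano. From the compounds shown here alone, whether a chlorine, a methoxy group or a tert-butyl group at this position would fall nearer compound 1 or nearer compound 3 remains open, as does whether the step would hold on a different substitution of the other ring.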